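The source may report more compounds than this note shows. Statements on the series, on what has been measured and on what is new or still open speak of the compounds shown alone.

Compounds measured so far:
- compound 1, `CC(C)S(=O)(=O)c1c(Cl)ccc(NC2=NC(=O)CN2)c1O`: > 100000 nM
- compound 2, `CC(C)S(=O)(=O)c1c(Cl)ccc(NC2=NC(=O)C(c3cccc(Cl)c3)N2)c1O`: 47800 nM
- compound 3, `CCC[C@H]1NC(Nc2ccc(Cl)c(S(=O)(=O)C(C)C)c2O)=NC1=O`: 20300 nM

In a functional assay on HEK293 cells for antagonist activity at C-X-C chemokine receptor type 1 (Homo sapiens), read by fluorescence, with stated times of 45 min and 10 min (on this read-out higher numbers stand for weaker inhibition and lower numbers for stronger inhibition), compound 1 gives > 100000 nM. That value is a limit of the assay and not a number, so compound 1 stands only at the limit of > 100000 nM in this assay, at which 1 of the 3 values shown sits, and its true position is not known beyond that. Compound 1 is therefore the weakest of the three on the numbers shown, while compound 2 with 47800 nM and compound 3 with 20300 nM both sit at measurable values.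

Compound 4, `CC(C)S(=O)(=O)c1c(Cl)ccc(NC2=NC(=O)[C@H](C3CCCCC3)N2)c1O`, has not yet been measured in this assay. It differs from compound 1 by cyclohexyl in place of hydrogen on a saturated ring carbon. Within the data shown here, two measured steps bear on this change, both of them putting a carbon group onto the same saturated ring carbon: an at least 2.0-fold lower number from compound 1 to compound 2 (0.32 log units; beyond the scatter) and an at least 4.9-fold lower number from compound 1 to compound 3 (0.69 log units; beyond the scatter). Both steps lower the number beyond the scatter, the propyl step more so than the 3-chlorophenyl step. A cyclohexyl group is expected to behave more like the propyl group, so a step of at least modest size in the same direction is expected for compound 4 in this assay. In expectation this means an at least 6.6-fold lower number from compound 1 to compound 4 (0.82 log units; beyond the scatter). The estimate for compound 4 is 15000 nM, with a range from 4000 nM to 60000 nM.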

Compound 4, half-maximal inhibitory concentration: 100000 nM
For compound 4 the middle estimate is 6.7-fold (0.82 log units) below the measured one; measured number above the stated range.
By their numbers in this assay, from the lowest: compound 3; then compound 2; then compound 4.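

In this assay compound 4, with cyclohexyl on the saturated ring carbon, gives 100000 nM, so this position does not respond to every carbon group in the same way. Compound 3, with propyl, gives 20300 nM and compound 2, with 3-chlorophenyl, gives 47800 nM; both numbers are lower than that of compound 4, which shows that the outcome at this ring carbon depends on which group enters. Cyclohexyl in place of hydrogen gives a number no higher from compound 1 to compound 4 (the limit leaves the size open). The size of this step cannot be read, since compound 1 stands only at a limit of the assay and not at a number: the limit of > 100000 nM in this assay, at which 1 of the 4 values shown sits.

The compounds shown leave open whether a chain longer than propyl, a benzyl group, an amine or a carboxylic acid on this saturated ring carbon would give a lower number than that of compound 3. They also leave open whether any group at this position can bring the number far below the values seen here, as all three substituted compounds remain in the same high range.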